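A few compounds are considered here, and "the series" means these few. Any claim that something is new, unique, unknown or untested is made for them only; others in the source may bear on it.

Of the compounds shown here, three with a shared core have so far been tested in an ADME assay on MT4 cells (Homo sapiens) for cytotoxicity; on this read-out lower numbers stand for higher toxicity in this test and higher numbers for lower toxicity in this test. Compound 1 `CCCCCc1cc(-c2cn([C@H]3C[C@H](OC(C)=O)[C@@H](COC(C)=O)O3)c(=O)[nH]c2=O)on1`, which carries a pentyl group, gives 3000 nM. Compound 2 `CC(=O)OC[C@H]1O[C@@H](n2cc(-c3cc(C)no3)c(=O)[nH]c2=O)C[C@@H]1OC(C)=O`, with methyl in that place, gives 3000 nM. Compound 3 `CC(=O)OC[C@H]1O[C@@H](n2cc(-c3cc(-c4ccc(C(C)C)cc4)no3)c(=O)[nH]c2=O)C[C@@H]1OC(C)=O`, with 4-isopropylphenyl there, gives 3000 nM, which puts it level with compound 1 and compound 2.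

Compound 4 `CCCCc1ccc(-c2cc(-c3cn([C@H]4C[C@H](OC(C)=O)[C@@H](COC(C)=O)O4)c(=O)[nH]c3=O)on2)cc1` has not yet been measured. It differs from compound 3 by one small edit: butyl in place of isopropyl on an aromatic carbon. In plain terms, butyl takes the place of isopropyl on an aromatic carbon, so 4-isopropylphenyl becomes 4-butylphenyl.

Within the data shown here, three measured steps bear on this edit, all made at the same spot on the core. Cutting the pentyl chain down to methyl gave no change at the digits printed from compound 1 to compound 2 (within the scatter). Replacing pentyl with 4-isopropylphenyl gave no change at the digits printed from compound 1 to compound 3 (within the scatter), and replacing methyl with 4-isopropylphenyl gave no change at the digits printed from compound 2 to compound 3 (within the scatter). These were all larger swaps than the one now in question, and none moved the value beyond the scatter. In this assay, then, no shift in either direction is expected, and the expected step is no change at the digits printed from compound 3 to compound 4 (within the scatter). For compound 4 the estimated value is 3000 nM, with an expected range from 1500 nM to 6000 nM.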

Compound 4, half-maximal cytotoxic concentration: 3000 nM
Compound 4: middle estimate and measured number agree at the digits printed; the range from low to high includes it.
By their numbers in this assay, from the lowest: compounds 1, 2, 3 and 4 (each within the scatter of the next).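

Putting butyl in place of isopropyl on the phenyl group in this assay gave no change at the digits printed from compound 3 to compound 4 (within the scatter), which extends the earlier picture to a small edit within the aryl substituent itself: a straight butyl chain and an isopropyl group at this place on the phenyl ring read alike in this test. Measured against the simple alkyl groups at the same spot on the shared core, 4-butylphenyl in place of methyl gave no change at the digits printed from compound 2 to compound 4 (within the scatter), and 4-butylphenyl in place of pentyl gave no change at the digits printed from compound 1 to compound 4 (within the scatter), so this fourth group also sits level with the short chain, the long chain and the other substituted phenyl. Nothing available here explains why these values stay level.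

Going by these compounds, all four groups at this spot are built of carbon and hydrogen only, so it remains open whether an amine or a carboxylic acid there would shift the value in this test. The compounds shown also leave open what happens when the change is made elsewhere on the shared core, for example a free hydroxyl group in place of either acetyl ester.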